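From phenethyl to 2-fluorophenyl on a carbonyl carbon

The compounds below may be only part of what the source reports. "The series", "measured", "known", "first", "only" and "open" are said of these compounds alone.

- Compound 1 (`Cc1cccc(C(=O)Nc2ncc(-c3ccccc3)n2C)c1`): (> 50000 nM), a limit
- Compound 2 (`COc1ccc(-c2cnc(NC(=O)CCc3ccccc3)n2C)cc1`): (> 100000 nM), a limit
- Compound 3 (`CCCn1c(-c2ccc(OC)cc2)cnc1NC(=O)c1ccc(F)cc1`): (> 100000 nM), a limit

All three compounds were tested in a toxicity assay on THP-1 cells (Homo sapiens) for inhibition (a higher number here means that more compound is tolerated, a lower number that less compound is tolerated), and none of them gave a number, only a limit. Compound 2 sits at the limit of > 100000 nM in this assay, at which 2 of the 3 values shown sit, and so gives no exact position. Compound 1 sits at the limit of > 50000 nM in this assay, at which 1 of the 3 values shown sits, and is likewise only a limit.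

Compound 4 (`COc1ccc(-c2cnc(NC(=O)c3ccccc3F)n2C)cc1`) differs from compound 2 by having 2-fluorophenyl in place of phenethyl on a carbonyl carbon. For the measured compounds named here, no measured step shows what such a change does. The closest guide is compound 3, with a fluorophenyl group on its carbonyl carbon, which again reaches a limit at (> 100000 nM). The expected change in this assay is none beyond the usual scatter, with the estimate reading (a number no higher from compound 2 to compound 4 (the limit leaves the size open)). The expected value for compound 4 is (100000 nM), within an estimated range of (45000 nM) to (200000 nM).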

Compound 4, half-maximal cytotoxic concentration: > 100000 nM
Compound 4 ended at the assay's limit (the forecaster's own chance of this, stated with the estimate: 85%); the middle value lies on the limit itself.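

For the compounds shown here, compound 2 and compound 4 both ended at a limit, so the change from phenethyl to 2-fluorophenyl on the carbonyl carbon gives no step that can be read. The compounds shown leave open at what concentration, if any, each stops being tolerated.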